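Dithiocarbamate amine variation on a shared isoflavone core

This account rests on a few compounds, and the source may have more. Where it says the series, first, only, none or still open, it means among the compounds named here.

Measured so far in a functional assay on ECa-109 cells for inhibition, with ECa-109 cell line (Homo sapiens) as the target, read by MTT assay, with a stated time of 48 h; on this read-out lower numbers stand for stronger inhibition and higher numbers for weaker inhibition: compound 1 `COc1ccc(-c2coc3cc(OCCCSC(=S)N4CCN(C)CC4)ccc3c2=O)cc1` gives 24200 nM; compound 2 `COc1ccc(-c2coc3cc(OCCCSC(=S)N4CCN(c5ccccn5)CC4)ccc3c2=O)cc1` gives 38300 nM.

Within the data shown here, compound 2 stands at the highest of the two numbers, with compound 1 as its only neighbour; the step of a 1.6-fold higher number from compound 1 to compound 2 (0.20 log units; within the scatter) lies within the scatter, so the two values give no order between them.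

Compound 3 `COc1ccc(-c2coc3cc(OCCCSC(=S)N4CCOCC4)ccc3c2=O)cc1` has not been measured. It differs from compound 2 by morpholin-4-yl in place of 4-(pyridin-2-yl)piperazin-1-yl on a thiocarbonyl carbon.

Among the measured compounds shown here, the only measured step that touches the group on the thiocarbonyl carbon is a 1.6-fold higher number from compound 1 to compound 2 (0.20 log units; within the scatter), and it stays within the scatter. For the measured compounds named here, no measured compound carries morpholin-4-yl at that place, so the present change has no direct precedent; the one exchange of the amine group that is known left the number essentially where it was. On that basis the step from compound 2 to compound 3 is expected to be a 1.3-fold lower number from compound 2 to compound 3 (0.11 log units; within the scatter), no movement beyond the scatter in this assay.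

Compound 3 is therefore estimated at 30000 nM in this assay, with a range of 12000 nM to 80000 nM.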

Compound 3, half-maximal inhibitory concentration: 34000 nM
Compound 3: the middle estimate sits 1.1-fold (0.05 log units) below what was measured, within the range that was stated.
By their numbers in this assay, from the lowest: compounds 1, 3 and 2 (each within the scatter of the next).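

In this assay the third amine group on the thiocarbonyl carbon adds a 1.1-fold lower number from compound 2 to compound 3 (0.05 log units; within the scatter) and a 1.4-fold higher number from compound 1 to compound 3 (0.15 log units; within the scatter) to the earlier step, so all three groups now sit within the scatter of one another and cannot be put in any order. The exchange for morpholin-4-yl is also a much larger structural change than the earlier one at this place: 4-(pyridin-2-yl)piperazin-1-yl with 12 heavy atoms and a six-membered aromatic ring gives way to a group with 6 heavy atoms and no aromatic ring, yet the number shows no movement beyond the scatter. No supporting data bear on why this read-out stays flat across the three groups.

Still open, on these data alone, is whether any amine group on the thiocarbonyl carbon, such as piperidin-1-yl, pyrrolidin-1-yl or diethylamino, moves the number beyond the scatter. Also open, as far as these compounds go, is whether a change elsewhere does so, such as a longer chain on the sulfur or a hydroxyl group in place of the methoxy group on the shared core.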